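A Methyl on the Amide Chain of Compound 3

The source may hold more compounds than are shown below. What is called first, only, known or untested is meant among the compounds shown, and "the series" means these compounds.

Of the compounds shown here, three built on one shared core have been measured in an assay on membranes from HeLa cells for displacement of a labelled ligand from adenosine receptor A3 (Homo sapiens), read by scintillation counting, with a stated time of 180 min, tested at 1 uM; a lower number here means less inhibition, a higher number more inhibition at the concentration tested (going by the name of the read-out). Compound 1 `CC(=O)C1=C(C)NC(=O)NC1c1ccsc1` gives 1%. Compound 2 `CC1=C(C(=O)NC(C)C)C(c2ccco2)NC(=O)N1` gives 4%. Compound 3 `CCNC(=O)C1=C(C)NC(=O)NC1c1ccsc1` gives 1%. Compound 3 thus stands level with compound 1 at the digits shown, the two together being the lowest of the three numbers; the number of compound 2 lies furthest from it, yet still within the scatter, so none of the three can be set apart from the others.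

Going by the values given here, the only measured step between compounds differing in one place is no change at the digits printed from compound 1 to compound 3 (within the scatter), where ethylamino replaced methyl on a carbonyl carbon. Compound 4 `CC1=C(C(=O)NC(C)C)C(c2ccsc2)NC(=O)N1` differs from compound 3 by methyl in place of hydrogen on a saturated chain carbon bound to an amide-type nitrogen and a saturated chain carbon. Cut one bond further out, the same change reads ethylcarbamoyl to isopropylcarbamoyl, so it touches the very group that the measured step put in place, and that step showed nothing beyond the scatter. Among the compounds with values here, no measured step points to a rise. The step of a number 1 percentage points higher from compound 3 to compound 4 (within the scatter) is therefore expected to lie within the scatter. Compound 4 is expected to give 2%, within a range from 0% to 12%.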

Compound 4, a percentage reported as inhibition, at one concentration (the size of the read-out at that concentration, not a potency): 1%
For compound 4 the middle estimate is 1 percentage points above the measured one; the range from low to high includes it.
By their numbers in this assay, from the lowest: compounds 1, 3, 4 and 2 (each within the scatter of the next).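

In this assay the added methyl, which turns ethylcarbamoyl into isopropylcarbamoyl, gives no change at the digits printed from compound 3 to compound 4 (within the scatter), so this first change on the amide chain itself leaves the reading where the shorter chain had it. Isopropylamino in place of methyl on the carbonyl carbon gives no change at the digits printed from compound 1 to compound 4 (within the scatter), matching what ethylamino showed there, and thiophen-3-yl in place of furan-2-yl on a saturated ring carbon, the first ring swap that can be read as a single step, gives a number 3 percentage points lower from compound 2 to compound 4 (within the scatter) and so adds no separation either. Nothing available explains why these changes read alike.

Going by these compounds, it remains open whether an amine or a carboxylic acid at the end of a longer chain on this amide would move the number. Also open, on these data alone, is whether any group on the shared core gives a reading beyond the scatter.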